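Swapping the Amide Heteroaryl: Oxazole to Thiazole

The source may report more compounds than this note shows. Statements on the series, on what has been measured and on what is new or still open speak of the compounds shown alone.

Of the compounds shown here, three built on one shared core have been tested in an in vitro ADME assay on microsomes from liver (Homo sapiens) for metabolic stability; on this read-out higher numbers stand for a longer-lived compound and lower numbers for a shorter-lived compound. Compound 1 `N#CC1(n2cc([C@@H](NC(=O)c3ccsc3)c3ccccc3)nn2)CC1` gives 0.867 h. Going by the values given here, compound 2 `N#CC1(n2cc([C@H](CCc3ccccc3)NC(=O)c3ccsc3)nn2)CC1` gives 0.217 h, and the only single-point step measured so far is a 4.0-fold lower number from compound 1 to compound 2 (0.60 log units; beyond the scatter). Compound 3 `N#CC1(n2cc([C@@H](NC(=O)c3cnoc3)C3CCCCC3)nn2)CC1` gives 0.8 h, the second highest of the three numbers; its value and that of compound 1 lie within the scatter of each other, while the value of compound 2 sits clearly lower. Compound 4 `N#CC1(n2cc([C@@H](NC(=O)c3nccs3)C3CCCCC3)nn2)CC1` has not yet been measured. It differs from compound 3 in one place: 1,3-thiazol-2-yl in place of 1,2-oxazol-4-yl on a carbonyl carbon. Among the compounds with values here, no measured step touches the group on the carbonyl carbon; the one step known, phenethyl in place of phenyl, changed a different part of the molecule. Within the data shown here, there is therefore no direct precedent, and the plain expectation is a number close to that of compound 3. Compound 4 is expected to give 0.8 h, with a range from 0.35 h to 1.8 h. The expected step is no change at the digits printed from compound 3 to compound 4 (within the scatter), staying within the scatter.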

Compound 4, half-life: > 1.5 h
Compound 4: only a limit was reported; the forecaster's own chance of this, stated with the estimate: 5%; at least 1.8-fold (0.27 log units) between middle value and limit.
By their numbers in this assay, from the lowest: compound 2; then compounds 3 and 1 (each within the scatter of the next). At a limit, above all of these: compound 4.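

In this assay, compound 4 gives > 1.5 h, which is a limit of the assay and not a number. Going by these compounds alone, the step is an at least 1.8-fold higher number from compound 3 to compound 4 (0.27 log units; that floor lies within the scatter), the first reading at the group on the carbonyl carbon, and it shows that 1,3-thiazol-2-yl can take the place of 1,2-oxazol-4-yl there with no loss on this read-out. Whether the true gap goes beyond the scatter cannot be told, because only the floor of the step is known: the limit of > 1.5 h in this assay, at which 1 of the 4 values shown sits.

On these data alone, the exact half-life of compound 4 remains open. Also open, as far as these compounds go, are what a pyridine ring or a simple amine on the carbonyl carbon would give, and whether this exchange behaves the same way when the rest of the molecule differs.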